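The compounds below may be only part of what the source reports. "The series", "measured", "known", "first", "only" and "open" are said of these compounds alone.

Two compounds of this set share the same long chain, amide and five-membered core and differ in how that core is built. Compound 1 `CCCCCCCCCCCCCCCCCCNC(=O)[C@@H]1CSC(c2cc(OC)c(OC)c(OC)c2)N1` gives 3900 nM in a functional assay on DU-145 cells (Homo sapiens) for antiproliferative activity, read by sulforhodamine B assay; on this read-out higher numbers stand for weaker inhibition and lower numbers for stronger inhibition. Compound 2 `CCCCCCCCCCCCCCCCCCNC(=O)[C@H]1NC(c2cc(OC)c(OC)c(OC)c2)SC1(C)C` carries two methyl groups on the ring carbon bearing the sulfur, and in this assay compound 2 returns only > 20000 nM, a limit of the assay rather than a number, so its true value is known only as sitting at the limit of > 20000 nM in this assay, at which 1 of the 2 values shown sits, or beyond it. Compound 3 `CCCCCCCCCCCCCCCCCCNC(=O)[C@H]1NC(c2ccc(N(C)C)cc2)SC1(C)C`, not yet measured, keeps the core of compound 2 and changes the aromatic group: 4-(dimethylamino)phenyl in place of 3,4,5-trimethoxyphenyl on a saturated ring carbon. Going by the values given here, with compound 2 known only as a limit, no measured step guides this change, and compound 3 is expected to remain weak, with an estimated step of a number no higher from compound 2 to compound 3 (the limit leaves the size open) in this assay. The estimated value for compound 3 is 20000 nM, in a range from 5000 nM to 60000 nM.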

Compound 3, half-maximal inhibitory concentration: > 20000 nM
Compound 3 ended at the assay's limit (the forecaster's own chance of this, stated with the estimate: 60%); the middle value lies on the limit itself.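

Compound 2 and compound 3 both end at a limit of the assay rather than at a number, so no step can be read between them: the limit of > 20000 nM in this assay, at which 2 of the 3 values shown sit.

The compounds shown leave open whether 4-(dimethylamino)phenyl in place of 3,4,5-trimethoxyphenyl changes the activity at all.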